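A few compounds are considered here, and "the series" means these few. Any claim that something is new, unique, unknown or untested is made for them only; others in the source may bear on it.

Compound 1 `CCS(=O)(=O)Nc1ccc(Oc2ccc(C#N)cc2)c(-c2cn(C)c(=O)c3[nH]ccc23)c1` is the starting point here. In an ADME assay on microsomes from liver (Homo sapiens) for metabolic stability, read by HPLC, using NADPH, with stated times of 5 min and 60 min, tested at 10 uM (a lower number here means slower removal, a higher number faster removal of the compound), compound 1 gives 41.7 mL/min/kg. Compound 2 `Cn1cc(-c2cc(NS(C)(=O)=O)ccc2Oc2cccnc2)c2cc[nH]c2c1=O` gives 86.7 mL/min/kg in this assay, so compound 1 has the lower of the two numbers. Compound 3 `Cn1cc(-c2cc(NS(C)(=O)=O)ccc2OC2CCC(F)(F)CC2)c2cc[nH]c2c1=O` returns only a limit of the assay in this assay, namely < 38.4 mL/min/kg, and not a number.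

The change from compound 1 to compound 4 `CCS(=O)(=O)Nc1ccc(OC2CCN(C)CC2)c(-c2cn(C)c(=O)c3[nH]ccc23)c1` is 1-methylpiperidin-4-yl in place of 4-cyanophenyl on an oxygen on an aromatic ring. Within the data shown here, the one measured step that resembles it is an at least 2.2-fold lower number from compound 2 to compound 3 (0.35 log units; beyond the scatter), where an aromatic ring on the oxygen was likewise exchanged for a saturated six-membered ring. By that comparison, compound 4 is expected to give a lower number than compound 1, a modest step of about a 1.5-fold lower number from compound 1 to compound 4 (0.17 log units; within the scatter). The expected value for compound 4 is 28 mL/min/kg, somewhere between 14 mL/min/kg and 50 mL/min/kg. Since that range overlaps (the limit of < 38.4 mL/min/kg in this assay, at which 1 of the 3 values shown sits), the assay may well report a limit for compound 4 rather than a number.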

Compound 4, clearance: < 28.4 mL/min/kg
Compound 4: only a limit was reported; the forecaster's own chance of this, stated with the estimate: 55%; the middle value does not contradict the limit.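

In this assay, compound 4 gives < 28.4 mL/min/kg, which is a limit of the assay and not a number. Exchanging the aromatic group on the oxygen for the saturated 1-methylpiperidin-4-yl ring gives an at least 1.4-fold lower number from compound 1 to compound 4 (0.16 log units; that floor lies within the scatter), so even the smallest step this limit allows cannot be told apart from the scatter. Even so, this is a second pair in which a saturated six-membered ring on the oxygen goes with a lower number than an aromatic ring, and here that saturated ring contains a nitrogen, unlike the 4,4-difluorocyclohexyl group of compound 3.

The true size of the step stays unknown because compound 4 reaches a limit: the limit of < 28.4 mL/min/kg in this assay, at which 1 of the 4 values shown sits.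

As far as these compounds go, it also remains open how a piperidine with a hydrogen in place of the methyl group on its nitrogen, or an open chain such as 2-methoxyethyl, would behave on this oxygen.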